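Swapping the Amide Ring: Pyridazine to Thiadiazole

This account rests on a few compounds, and the source may have more. Where it says the series, first, only, none or still open, it means among the compounds named here.

Measured so far:
Compound 1 `CC(C)[C@H](C(=O)NC(C)(C)C)c1ccc(Cl)cc1` gives a limit of the assay, < 30%.
Compound 2 `CC(C)[C@H](C(=O)Nc1ccc(F)cn1)c1ccc(Cl)cc1` gives 93%.
Compound 3 `CC(C)[C@H](C(=O)Nc1cccnn1)c1ccc(Cl)cc1` gives 101%.

In a functional assay on CHO cells for agonist activity at Free fatty acid receptor 2 (Homo sapiens), read by cAMP accumulation (on this read-out higher numbers stand for larger maximal responses and lower numbers for smaller maximal responses), compound 3 and compound 2 sit within the usual scatter of each other, as a number 8 percentage points higher from compound 2 to compound 3 (within the scatter) shows. Compound 1 stands at the limit of < 30% in this assay, at which 1 of the 3 values shown sits. Compound 4 `CC(C)[C@H](C(=O)Nc1ncns1)c1ccc(Cl)cc1` is not yet measured; it differs from compound 3 by 1,2,4-thiadiazol-5-yl in place of pyridazin-3-yl on an amide-type nitrogen. The measured steps that bear on this are a number at least 71 percentage points higher from compound 1 to compound 3 (beyond the scatter) and a number at least 63 percentage points higher from compound 1 to compound 2 (beyond the scatter), both large, and a number 8 percentage points higher from compound 2 to compound 3 (within the scatter), which exchanged one aromatic ring for another on the amide-type nitrogen without moving beyond the scatter. Since compound 4 keeps an aromatic ring in that place, the step of a number 6 percentage points lower from compound 3 to compound 4 (within the scatter) is expected to stay within the scatter. Compound 4 is therefore estimated at 95%, between 70% and 110%.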

Compound 4, largest response reached (reported as efficacy), in percent of the reference or control that the assay uses: 99%
Beside the measured number, compound 4's estimate is 4 percentage points below it, and the stated range covers the measured number.
By their numbers in this assay, from the lowest: compounds 2, 4 and 3 (each within the scatter of the next). At a limit, below all of these: compound 1.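

In this assay, the five-membered 1,2,4-thiadiazol-5-yl ring, which brings in sulfur, fits this place on the amide-type nitrogen as well as the six-membered rings do, with a number 2 percentage points lower from compound 3 to compound 4 (within the scatter) and a number 6 percentage points higher from compound 2 to compound 4 (within the scatter). The gain over tert-butyl therefore extends to a third aromatic ring, with a number at least 69 percentage points higher from compound 1 to compound 4 (beyond the scatter). Compound 1 remains a limit of the assay: the limit of < 30% in this assay, at which 1 of the 4 values shown sits.

Going by these compounds, what a plain phenyl or a saturated cyclohexyl ring would give on this nitrogen stays open. So does the effect of adding a carboxylic acid to the thiadiazole ring.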